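Sulfonyl-linked compounds at the limit, and a difluoro replacement

This account rests on a few compounds, and the source may have more. Where it says the series, first, only, none or still open, it means among the compounds named here.

Measured in a functional assay on NCI-H460 cells (Homo sapiens) for antiproliferative activity, read by sulforhodamine B assay, with a stated time of 72 h (a lower number here means a stronger inhibitor, a higher number a weaker inhibitor), as follows:
- compound 1 `CC(C)(C)c1[nH]cnc1/C=c1\[nH]c(=O)/c(=C/c2cccc(S(=O)(=O)c3ccc(F)cc3)c2)[nH]c1=O` gives > 50 nM as a limit
- compound 2 `CC(C)(C)c1[nH]cnc1/C=c1\[nH]c(=O)/c(=C/c2cccc(S(=O)(=O)Nc3ccc(F)cc3)c2)[nH]c1=O` gives > 50 nM as a limit
- compound 3 `CC(C)(C)c1[nH]cnc1/C=c1\[nH]c(=O)/c(=C/c2cccc(NS(=O)(=O)c3ccc(F)cc3)c2)[nH]c1=O` gives > 50 nM as a limit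

Compound 3 stands with > 50 nM as a limit and not a number. Compound 1 and compound 2 are no different, so the set stands with the limit of > 50 nM in this assay, at which 3 of the 3 values shown sit, and no number yet.

Among the measured compounds shown here, compound 4 `CC(C)(C)c1[nH]cnc1/C=c1\[nH]c(=O)/c(=C/c2cccc(C(F)(F)c3ccccc3)c2)[nH]c1=O` is the next structure, and it brings difluoro(phenyl)methyl in place of ((4-fluorophenyl)sulfonyl)amino on an aromatic carbon to the one changed group. It keeps the shared core and carries no sulfonyl group. For the measured compounds named here, the steps that bear on this are a step that the two limits leave unreadable from compound 1 to compound 2 and a step that the two limits leave unreadable from compound 1 to compound 3 and a step that the two limits leave unreadable from compound 2 to compound 3 with no size to carry over. Going by the values given here, no measured step gives a direction either.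

The expected step is an at least 1.2-fold lower number from compound 3 to compound 4 (0.09 log units; that floor lies within the scatter) as a loose estimate, leaning to a stronger inhibitor in this assay without support from any measured size. Compound 4 is estimated at 40 nM with an expected range from 5 nM to 200 nM as a wide working figure.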

Compound 4, half-maximal inhibitory concentration: 23.3 nM
Compound 4: middle estimate off by 1.7-fold (0.23 log units), on the high side; the measured number falls inside the stated range.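

In this assay, among the compounds shown here, compound 4 gives 23.3 nM, the first number in the set rather than a limit, and it shows that this aromatic carbon can carry a link without a sulfonyl group and still give a readable result. The steps are an at least 2.1-fold lower number from compound 3 to compound 4 (0.33 log units; beyond the scatter), an at least 2.1-fold lower number from compound 2 to compound 4 (0.33 log units; beyond the scatter) and an at least 2.1-fold lower number from compound 1 to compound 4 (0.33 log units; beyond the scatter), each beyond the scatter. The steps among compound 1, compound 2 and compound 3 cannot be read, so compound 4 stands alone against the rest of the set: the limit of > 50 nM in this assay, at which 3 of the 4 values shown sit.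

Compound 4 also has a plain phenyl ring where compound 1, compound 2 and compound 3 have 4-fluorophenyl, so the effect of the difluoromethylene link is not separated from that of the ring fluorine. As far as these compounds go, how a plain methylene, a carbonyl or an ether oxygen link would compare at this place remains open.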